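The source may hold more compounds than are shown below. What is called first, only, known or untested is meant among the compounds shown, and "the series" means these compounds.

In a functional assay on G-361 cells (Homo sapiens) for cytotoxicity, read by fluorescence, with a stated time of 72 h (a lower number here means a stronger inhibitor, a higher number a weaker inhibitor), compound 1 `CSc1nc(NCc2ccc(-c3ccccn3)cc2)c2[nH]nc(C(C)C)c2n1` gives 1400 nM, compound 2 `CC(C)c1n[nH]c2c(NCc3ccc(-c4ccccn4)cc3)nc(N3CCCCC3CCO)nc12` gives 204 nM and compound 3 `CC(C)c1n[nH]c2c(NCc3ccc(-c4ccccn4)cc3)nc(NCCN)nc12` gives 230 nM. Compound 3 thus belongs to the lower pair of the three numbers, as shown by a 6.1-fold lower number from compound 1 to compound 3 (0.78 log units; beyond the scatter) and by a 1.1-fold higher number from compound 2 to compound 3 (0.05 log units; within the scatter). The first replacement of methylsulfanyl gave a similar change, a 6.9-fold lower number from compound 1 to compound 2 (0.84 log units; beyond the scatter). Compound 4 `CC(C)c1n[nH]c2c(NCc3ccc(-c4ccccn4)cc3)nc(NCCN(C)C)nc12` differs by one change, dimethylamino in place of amino on a saturated chain carbon, two bonds along the chain from a nitrogen on an aromatic ring. Among the compounds with values here, no measured step alters this amino group directly, so the evidence is indirect. Two quite different groups in compound 2 and compound 3 gave matching numbers, so no shift beyond the scatter is expected. For compound 4 the expected step is a 1.2-fold lower number from compound 3 to compound 4 (0.06 log units; within the scatter). Compound 4 is estimated at 200 nM, with an expected range of 90 nM to 450 nM.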

Compound 4, half-maximal inhibitory concentration: 640 nM
Estimate against measurement, compound 4: 3.2-fold (0.51 log units) below, and the stated range ends below it.
By their numbers in this assay, from the lowest: compounds 2 and 3 (each within the scatter of the next); then compound 4; then compound 1.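

In this assay this position proves sensitive to the change, dimethylamino in place of amino on a saturated chain carbon, with a 2.8-fold higher number from compound 3 to compound 4 (0.44 log units; beyond the scatter), even though very different groups had earlier given matching numbers. The (2-(dimethylamino)ethyl)amino group also falls short of 2-(2-hydroxyethyl)piperidin-1-yl, with a 3.1-fold higher number from compound 2 to compound 4 (0.50 log units; beyond the scatter), yet it still improves on methylsulfanyl, with a 2.2-fold lower number from compound 1 to compound 4 (0.34 log units; beyond the scatter). Nothing available explains the size of these steps. As far as these compounds go, it remains open how a methylamino group, a pyrrolidin-1-yl group or a longer chain carrying the amino group would behave here.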